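Urea-linked series: removing the methylene spacer

This account rests on a few compounds, and the source may have more. Where it says the series, first, only, none or still open, it means among the compounds named here.

Assay and standing. In an ADME assay on the whole organism (Rattus norvegicus, strain Sprague-Dawley) for metabolic stability, read by LC-MS, with a stated time of 24 h (a higher number here means that the compound lasts longer, a lower number that the compound disappears faster), compound 2 `COc1ccc(CNC(=O)Nc2ccc(Oc3ncnc4cc(N(C)C)ccc34)cc2)cn1` gives 4.8 h, the lowest of the two numbers seen so far; its nearest neighbour, compound 1 `COc1ccc(CNC(=O)Nc2ccc(Oc3ncnc4cc(N(C)C)ccc34)cc2)cc1`, gives 6.7 h in this assay, and a 1.4-fold lower number from compound 1 to compound 2 (0.14 log units; within the scatter).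

Change to the next compound. Compound 3 `COc1ccc(NC(=O)Nc2ccc(Oc3ncnc4cc(N(C)C)ccc34)cc2)cc1` differs from compound 2 by 4-methoxyphenyl in place of (6-methoxypyridin-3-yl)methyl on an amide-type nitrogen.

Bearing of measured steps. Among the measured compounds shown here, the only step in hand, a 1.4-fold lower number from compound 1 to compound 2 (0.14 log units; within the scatter), concerns the aryl swap alone and says nothing about dropping the chain carbon; it also ran within the scatter. For the measured compounds named here, no measured pair covers the chain removal, so no direction beyond the scatter can be taken from the data.

Expectation. The step of a 1.3-fold higher number from compound 2 to compound 3 (0.10 log units; within the scatter) is expected to stay within the scatter, with the estimate for compound 3 at 6 h in this assay, its range running from 2.5 h to 14 h.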

Compound 3, half-life: 4 h
Compound 3: the middle estimate sits 1.5-fold (0.18 log units) above what was measured, within the range that was stated.
By their numbers in this assay, from the lowest: compounds 3, 2 and 1 (each within the scatter of the next).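

Among the compounds shown here, on the amide-type nitrogen, 4-methoxyphenyl in place of 4-methoxybenzyl gives the first reading in this assay of a change that removes the saturated chain carbon and leaves the methoxy-bearing ring as it is (a 1.7-fold lower number from compound 1 to compound 3 (0.22 log units; within the scatter)). The change from (6-methoxypyridin-3-yl)methyl to 4-methoxyphenyl alters the ring and the chain together and also stays within the scatter (a 1.2-fold lower number from compound 2 to compound 3 (0.08 log units; within the scatter)), so across these three compounds the half-life does not separate an aryl group bound directly to this nitrogen from one held on a chain carbon. Nothing in hand gives a reason for this outcome.

Open, on these data alone, is whether a longer chain on this nitrogen, such as 2-(4-methoxyphenyl)ethyl, would also stay within the scatter. Also open, as far as these compounds go, is how a primary amine or a carboxylic acid in place of the methoxy group would read in this assay.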